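Swapping a nitro-bearing ring for a methyl-bearing one

The compounds below may be only part of what the source reports. "The series", "measured", "known", "first", "only" and "open" are said of these compounds alone.

Compound 1 `O=C(Nc1cc(Sc2ncn[nH]2)c(O)c2ccccc12)c1ccc([N+](=O)[O-])cc1` carries a 4-nitrophenyl on its amide carbonyl. In a functional assay on MDA-MB-231 cells (Homo sapiens) for antiproliferative activity, read by MTT assay, with a stated time of 48 h (on this read-out higher numbers stand for weaker inhibition and lower numbers for stronger inhibition), compound 1 gives only a limit, > 100000 nM, so its true value is not known, and the limit of > 100000 nM in this assay, at which 1 of the 2 values shown sits, marks that one of the two measured values sits there. Compound 2 `O=C(Nc1cc(Sc2ncnc3nc[nH]c23)c(O)c2ccccc12)c1ccc(Cl)cc1` has a different ring system on the sulfur and a chlorine on the benzamide; in this assay compound 2 gives 23000 nM. Compound 3 `Cc1cccc(C(=O)Nc2cc(Sc3ncn[nH]3)c(O)c3ccccc23)c1` differs from compound 1 by 3-methylphenyl in place of 4-nitrophenyl on a carbonyl carbon. With no number for compound 1, the step of an at least 2.0-fold lower number from compound 1 to compound 3 (0.30 log units; that floor lies within the scatter) is only an expectation of modestly stronger inhibition. Compound 3 is estimated at 50000 nM, between 15000 nM and 200000 nM.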

Compound 3, half-maximal inhibitory concentration: > 100000 nM
Compound 3 was reported as a limit; the forecaster's own chance of this, stated with the estimate: 45%; middle value at least 2.0-fold (0.30 log units) away from the limit.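

Compound 1 and compound 3 both end at a limit of the assay, so no step between them can be read: the limit of > 100000 nM in this assay, at which 2 of the 3 values shown sit.

Going by these compounds, whether 3-methylphenyl or 4-nitrophenyl on a carbonyl carbon gives the stronger inhibition in this assay stays open.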